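The source may report more compounds than this note shows. Statements on the series, on what has been measured and on what is new or still open speak of the compounds shown alone.

Working notes on the series. Two compounds have numbers in a functional assay (Homo sapiens) for inhibition; on this read-out lower numbers stand for stronger inhibition and higher numbers for weaker inhibition. Compound 1, `CSc1cccc(CSc2nc(-c3ccc(F)cc3)c(-c3ccncc3)[nH]2)c1`, gives 550 nM in this assay and stands lowest of the two. Compound 2, `CS(=O)(=O)c1ccc(CSc2nc(-c3ccccc3)c(-c3ccncc3)[nH]2)cc1`, gives 1700 nM in this assay; it differs from compound 1 in more than one place, so the two values are set side by side without a single step read from them.

Compound 3, `C[S+]([O-])c1ccc(O)c(CSc2nc(-c3ccc(F)cc3)c(-c3ccncc3)[nH]2)c1`, is not yet measured in this assay. It differs from compound 1 by a group of 10 heavy atoms (7 carbon, 2 oxygen, 1 sulfur; one six-membered aromatic ring of carbon only) in place of a group of 8 heavy atoms (7 carbon, 1 sulfur; one six-membered aromatic ring of carbon only), on a saturated chain carbon bound to a sulfur. The incoming group carries a hydrogen-bond donor and a second acceptor where the outgoing group has none of the former and one of the latter.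

No measured pair in the series isolates a change of this kind, so nothing shown fixes the direction. The step from compound 1 to compound 3 is expected to stay small, a 1.3-fold higher number from compound 1 to compound 3 (0.10 log units; within the scatter), likely within the scatter. Compound 3 is therefore estimated at 700 nM in this assay, with a range from 200 nM to 2500 nM.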

Compound 3, half-maximal inhibitory concentration: 1000 nM
The estimate for compound 3 lay 1.4-fold (0.15 log units) below the measured number, and the stated range covers the measured number.
By their numbers in this assay, from the lowest: compounds 1, 3 and 2 (each within the scatter of the next, the first and the last beyond it).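

In this assay, going by these compounds alone, a group of 10 heavy atoms, carrying a hydrogen-bond donor and a second acceptor, replaces 3-(methylsulfanyl)phenyl on a saturated chain carbon bound to a sulfur, giving a 1.8-fold higher number from compound 1 to compound 3 (0.26 log units; within the scatter) as the first single-place step. The position therefore takes this larger group with no change that can be told from the scatter, and the read-out does not separate the two compounds. No supporting data bear on why this exchange leaves the number within the scatter.

This one step cannot tell the contribution of the hydroxyl from that of the sulfoxide, as both enter together. Also open, on these data alone, is how an amine or a carboxylic acid on the aromatic ring, or a longer chain at the saturated carbon, would read at this position.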